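Methoxy in place of chloro: compound 4

This account rests on a few compounds, and the source may have more. Where it says the series, first, only, none or still open, it means among the compounds named here.

Within the data shown here, compound 3 `O=C(N/N=C/c1cccc(Cl)c1)c1cccnc1Nc1cccc(C(F)(F)F)c1` gives 63.5% in a functional assay on the whole organism (strain Wistar) for inhibition, with Rattus norvegicus as the target, read by paw edema, with a stated time of 2 h, at a dose of 10 mg/kg by the intraperitoneal route (on this read-out higher numbers stand for more inhibition at the one dose given (going by the name of the read-out) and lower numbers for less inhibition), the highest of the three numbers so far. Compound 2 `O=C(N/N=C/c1cccc(F)c1)c1cccnc1Nc1cccc(C(F)(F)F)c1` gives 52.8% and compound 1 `O=C(N/N=C/c1ccccc1)c1cccnc1Nc1cccc(C(F)(F)F)c1` gives 36.8%. The measured steps run a number 16 percentage points higher from compound 1 to compound 2 (beyond the scatter), a number 26.7 percentage points higher from compound 1 to compound 3 (beyond the scatter) and a number 10.7 percentage points higher from compound 2 to compound 3 (beyond the scatter): each substituent in this position raised the number against hydrogen, chloro more than fluoro. Compound 4 `COc1cccc(/C=N/NC(=O)c2cccnc2Nc2cccc(C(F)(F)F)c2)c1` differs from compound 3 by methoxy in place of chloro on an aromatic carbon. Among the measured compounds shown here, no measured step exchanges chloro for methoxy; the only step that bears on it is the exchange of chloro for fluoro, where compound 2 stands below compound 3 by a number 10.7 percentage points higher from compound 2 to compound 3 (beyond the scatter). A downward step of similar size, a number 11.5 percentage points lower from compound 3 to compound 4 (beyond the scatter), is therefore expected. Compound 4 is estimated at 52%, within 38% to 66%.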

Compound 4, a percentage reported as inhibition, in the whole organism at one dose (the size of the read-out at that dose, not a potency): 49.7%
Compound 4: the middle estimate sits 2.3 percentage points above what was measured; low and high end bracket the measured number.
By their numbers in this assay, from the lowest: compound 1; then compounds 4 and 2 (each within the scatter of the next); then compound 3.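

Methoxy on this aromatic carbon keeps a gain over hydrogen, with a number 12.9 percentage points higher from compound 1 to compound 4 (beyond the scatter) in this assay as the measure, but it does not reach chloro, with a number 13.8 percentage points lower from compound 3 to compound 4 (beyond the scatter) on the same read-out. Against fluoro, the exchange gives a number 3.1 percentage points lower from compound 2 to compound 4 (within the scatter) and no order can be drawn between those two groups, so chloro alone stands clear of every other group shown. No measured information accounts for this ranking.

Still open, on these data alone, is how an amine, a carboxylic acid or a longer chain such as ethoxy would fare at this place. The compounds shown also leave open whether the lead of chloro holds elsewhere on this ring.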